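The compounds below may be only part of what the source reports. "The series", "measured", "known", "first", "only" and "open" are said of these compounds alone.

Measured compounds:
Compound 1 `C=CCNC(=O)C(=O)C(CCC)NC(=O)[C@@H]1[C@@H]2[C@H](CN1C(=O)[C@@H](NC(=O)N[C@@H](CN1CCCCC1=O)C(C)(C)C)C1Cc3ccccc3C1)C2(C)C` gives 489 ng.h/mL
Compound 2 `C=CCNC(=O)C(=O)C(CC1CC1)NC(=O)[C@@H]1[C@@H]2[C@H](CN1C(=O)[C@@H](NC(=O)N[C@@H](CN1CCC(C)(C)CC1=O)C(C)(C)C)C(C)(C)C)C2(C)C` gives 2460 ng.h/mL

In an ADME assay on the whole organism (plasma) for pharmacokinetics, with Rattus norvegicus as the target, at a dose of 10 mg/kg by the oral route (on this read-out higher numbers stand for higher exposure at the dose given and lower numbers for lower exposure), compound 1 stands lowest of the two numbers; its nearest neighbour is compound 2, whose number is higher by a gap that lies beyond the scatter. No single-point step between the two measured compounds is known, and they differ in more than one place, so their values are only shown side by side. Compound 3 `C=CCNC(=O)C(=O)C(CCC)NC(=O)[C@@H]1[C@@H]2[C@H](CN1C(=O)[C@@H](NC(=O)N[C@@H](CN1CCCCC1=O)C(C)(C)C)C1CCCCC1)C2(C)C` is not yet measured. It differs from compound 1 in one place: cyclohexyl in place of 2,3-dihydro-1H-inden-2-yl on a saturated chain carbon bound to an amide-type nitrogen and a carbonyl carbon. Going by the values given here, the two measured compounds give no step that isolates this change, so the expected direction rests on the bare comparison of compound 1 with compound 2. A modest rise is expected, the step of a 1.6-fold higher number from compound 1 to compound 3 (0.21 log units; within the scatter) staying near the edge of the scatter. Compound 3 is therefore estimated at 800 ng.h/mL in this assay, with a range from 250 ng.h/mL to 2500 ng.h/mL.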

Compound 3, area under the concentration-time curve: 479 ng.h/mL
For compound 3 the middle estimate is 1.7-fold (0.22 log units) above the measured one, and the stated range covers the measured number.
By their numbers in this assay, from the lowest: compounds 3 and 1 (each within the scatter of the next); then compound 2.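

Cyclohexyl in place of 2,3-dihydro-1H-inden-2-yl gives a 1.0-fold lower number from compound 1 to compound 3 (0.01 log units; within the scatter) in this assay, the only single-place step at this position. Although the entering group has 6 heavy atoms in place of 9 and no six-membered aromatic ring, the two groups cannot be told apart on this read-out. No measurement shown explains this result.

Compound 2 differs from compound 1 in more than one place, so its place in this assay cannot be assigned to any single group. It remains open how this position would respond to a group bearing an amine or a carboxylic acid, such as a piperidin-4-yl ring or a carboxycyclohexyl group, since both carbon-only groups shown carry neither.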